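Cyclohexyl in Place of Acetoxymethyl: An Expected Inhibitory Concentration

The source may hold more compounds than are shown below. What is called first, only, known or untested is meant among the compounds shown, and "the series" means these compounds.

Compound 1 `COc1ccc(C(=O)/C(=C/c2ccc(Cl)cc2Cl)CCOC(C)=O)cc1` gives 83400 nM in a functional assay on MCF7 cells (Homo sapiens) for inhibition, read by XTT assay, with a stated time of 48 h (on this read-out higher numbers stand for weaker inhibition and lower numbers for stronger inhibition), the only numerical result among the two values shown. Compound 2 `COc1ccc(C(=O)/C(=C/c2ccc(Cl)cc2)CCOC(C)=O)cc1` reached only a limit of the assay, > 100000 nM in this assay, which is what the limit of > 100000 nM in this assay, at which 1 of the 2 values shown sits, records. Among the compounds with values here, the single measured step, an at least 1.1-fold higher number from compound 1 to compound 2 (0.07 log units; that floor lies within the scatter), concerns hydrogen in place of chloro on an aromatic carbon and so touches a different part of the shared core.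

Compound 3 `COc1ccc(C(=O)/C(=C/c2ccc(Cl)cc2Cl)CC2CCCCC2)cc1` differs from compound 1 by cyclohexyl in place of acetoxymethyl on a saturated chain carbon bound to a double-bonded chain carbon. Within the data shown here, no measured step bears on this change. With nothing to point either way, the step of a 1.4-fold lower number from compound 1 to compound 3 (0.14 log units; within the scatter) is expected to stay within the usual scatter. Compound 3 is therefore estimated at 60000 nM in this assay, with a range from 20000 nM to 200000 nM.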

Compound 3, half-maximal inhibitory concentration: > 100000 nM
Compound 3 was reported as a limit (the forecaster's own chance of this, stated with the estimate: 35%); middle value at least 1.6-fold (0.22 log units) away from the limit.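

At the saturated chain carbon bound to a double-bonded chain carbon, the change from acetoxymethyl to cyclohexyl now has a measured step in this assay, an at least 1.1-fold higher number from compound 1 to compound 3 (0.07 log units; that floor lies within the scatter). This step does not show that the change moves the read-out in either direction, as its floor stays within the scatter. Compound 3 gives a limit of the assay and not a number, so only that floor can be stated for this change: the limit of > 100000 nM in this assay, at which 2 of the 3 values shown sit.

As far as these compounds go, how far the true value of compound 3 lies from that of compound 1 remains open. From the compounds shown here alone, it is also open whether a carboxylic acid, an amine or a longer chain at this position would give a lower number than compound 1 in this assay.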